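The source may report more compounds than this note shows. Statements on the series, on what has been measured and on what is new or still open speak of the compounds shown alone.

Compound 1 `Cc1nc(-c2cccnc2)sc1-c1nnc(-c2ccccc2Cl)o1` is the starting point. In an ADME assay on HeLa cells (Homo sapiens) for cytotoxicity, read by MTT assay (a lower number here means that less compound is tolerated, a higher number that more compound is tolerated), compound 1 gives > 100 ug/mL, which is a limit of the assay rather than a number. Compound 2 `Cc1cccc(-c2nnc(-c3sc(-c4cccnc4)nc3C)o2)c1` gives > 100 ug/mL in this assay, also a limit. Compound 3 `Cc1nc(-c2cccnc2)sc1-c1nnc(-c2ccc(O)cc2)o1` gives > 100 ug/mL in this assay, again a limit. Among the compounds with values here, because all three values sit at the limit of > 100 ug/mL in this assay, at which 3 of the 3 values shown sit, the step that the two limits leave unreadable from compound 1 to compound 2, the step that the two limits leave unreadable from compound 1 to compound 3 and the step that the two limits leave unreadable from compound 2 to compound 3 cannot be sized: exchanging that ring on the shared core has brought no compound into the range where a number is read. Compound 4 `Cc1nc(-c2cccnc2)sc1-c1nnc(-c2cccnc2)o1` is not yet measured. It differs from compound 1 by pyridin-3-yl in place of 2-chlorophenyl on an aromatic carbon. The measured steps that bear on this change are the three exchanges of the same ring, and none of them is readable. The expected step in this assay is a step that the limit leaves unreadable from compound 1 to compound 4, which is to say none beyond the scatter. The estimate for compound 4 in this assay is 150 ug/mL, ranging from 70 ug/mL to 300 ug/mL, most likely reported only as a limit.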

Compound 4, half-maximal cytotoxic concentration: > 100 ug/mL
Compound 4 was reported as a limit; the forecaster's own chance of this, stated with the estimate: 85%; the middle value is on the limit's open side.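

In this assay compound 4 gives > 100 ug/mL, again a limit. No step between compound 4 and compound 1, compound 2 or compound 3 can be read, because all four compounds share one limit: the limit of > 100 ug/mL in this assay, at which 4 of the 4 values shown sit.

The compounds shown leave open whether exchanging this ring changes the half-maximal cytotoxic concentration at all.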